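The source may report more compounds than this note shows. Statements on the series, on what has been measured and on what is new or still open speak of the compounds shown alone.

Series notes.
Compound 1 `NC(=O)Cc1ccccc1-c1ccc(COC2CC[C@H](N3CCCCCC3)[C@H]2OC/C=C\CCC(=O)O)cc1`: 158 nM
Compound 2 `CS(=O)(=O)Nc1cccc(-c2ccc(COC3CC[C@H](N4CCCCCC4)[C@H]3OC/C=C\CCC(=O)O)cc2)c1`: 50.1 nM

Both are measured in a functional assay for antagonist activity at thromboxane A2 receptor (Rattus norvegicus); a lower number here means tighter binding, a higher number weaker binding. Compound 2 holds the lowest number of the two; its nearest neighbour is compound 1, and the step of a 3.2-fold lower number from compound 1 to compound 2 (0.50 log units; beyond the scatter) lies beyond the scatter. Compound 3 `O=C(O)CC/C=C\CO[C@H]1C(OCc2ccc(-c3ccc(CO)cc3)cc2)CC[C@@H]1N1CCCCCC1` has not been measured. It differs from compound 2 in one place: 4-(hydroxymethyl)phenyl in place of 3-(methanesulfonamido)phenyl on an aromatic carbon. Among the compounds with values here, the only measured step bearing on this position is a 3.2-fold lower number from compound 1 to compound 2 (0.50 log units; beyond the scatter), which exchanged the substituent on the same aromatic carbon and was modest. Within the data shown here, no measured step covers the entry of 4-(hydroxymethyl)phenyl, so the expectation rests on that single step and on the fact that compound 2, which carries the group that leaves, holds the lowest number. A modest rise in this assay is expected, roughly back towards the value of compound 1 158 nM. Compound 3 is estimated at 120 nM, with a range of 40 nM to 400 nM, corresponding to an expected step of a 2.4-fold higher number from compound 2 to compound 3 (0.38 log units; beyond the scatter).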

Compound 3, dissociation constant: 20 nM
Compound 3: the middle estimate sits 6.0-fold (0.78 log units) above what was measured, outside the stated range (below it).
By their numbers in this assay, from the lowest: compound 3; then compound 2; then compound 1.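

In this assay, the step of a 2.5-fold lower number from compound 2 to compound 3 (0.40 log units; beyond the scatter) shows that the methanesulfonamido group is not needed for a low number at this aromatic carbon: 4-(hydroxymethyl)phenyl, the smaller group by heavy atoms, gives the lowest number of the series. The step of a 7.9-fold lower number from compound 1 to compound 3 (0.90 log units; beyond the scatter) shows that the choice of group at this one place spans more of this assay than the first step alone revealed. No measured evidence available here accounts for this change.

The two groups differ both in the substituent and in the number of its position on the phenyl, and these two contributions remain unseparated. From the compounds shown here alone, it also remains open whether an aminomethyl group or a carboxylic acid in place of the hydroxymethyl would keep the number this low.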